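Amino in place of chloro on the pyridine ether

A few compounds are considered here, and "the series" means these few. Any claim that something is new, unique, unknown or untested is made for them only; others in the source may bear on it.

In an assay on isolated protein for inhibition of tyrosine-protein kinase receptor UFO (Homo sapiens), read by FRET and Z'-LYTE, with a stated time of 1.5 h (on this read-out lower numbers stand for stronger inhibition and higher numbers for weaker inhibition), compound 3 `CCc1ccc2c(c1)c(=O)c(C(=O)Nc1ccc(Oc3ccnc(Cl)c3)c(F)c1)c(C)n2C` gives only a limit, > 10000 nM. Compound 1 `Cc1c(C(=O)Nc2ccc(Oc3ncnc4[nH]cc(-c5ccccc5)c34)c(F)c2)c(=O)c2cc(F)ccc2n1C` likewise gives only a limit, > 10000 nM. Compound 2 `CCc1ccc2c(c1)c(=O)c(C(=O)Nc1ccc(Oc3ncnc4[nH]ccc34)c(F)c1)c(C)n2C` gives 157 nM, and the change of the ether aryl group brings an at least 63-fold higher number from compound 2 to compound 3 (1.80 log units; beyond the scatter), a step that ends at the limit of > 10000 nM in this assay, at which 2 of the 3 values shown sit. Compound 4 `CCc1ccc2c(c1)c(=O)c(C(=O)Nc1ccc(Oc3ccnc(N)c3)c(F)c1)c(C)n2C` differs from compound 3 by amino in place of chloro on an aromatic carbon, on an aromatic carbon of the six-membered aromatic ring with one nitrogen, next to the ring nitrogen. Within the data shown here, no measured step exchanges a substituent on this ring, so none bears directly on the change; the only step touching this part of the molecule is the large loss in an at least 63-fold higher number from compound 2 to compound 3 (1.80 log units; beyond the scatter). Compound 4 is therefore expected to stay weak, at an estimated 6000 nM with a range of 1000 nM to 30000 nM. The expected step of an at least 1.6-fold lower number from compound 3 to compound 4 (0.22 log units; that floor lies within the scatter) is estimated to be small.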

Compound 4, half-maximal inhibitory concentration: 888 nM
Estimate against measurement, compound 4: 6.8-fold (0.83 log units) above; measured number below the stated range.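

In this assay, a single substituent on the six-membered aromatic ring decides much of the read-out: amino in place of chloro gives an at least 11-fold lower number from compound 3 to compound 4 (1.05 log units; beyond the scatter). That step is only a floor, as its starting point is a limit of the assay: the limit of > 10000 nM in this assay, at which 2 of the 4 values shown sit. The 2-aminopyridin-4-yl group recovers much of the loss seen with the 2-chloropyridin-4-yl group, though a gap remains, with a 5.7-fold higher number from compound 2 to compound 4 (0.75 log units; beyond the scatter).

From the compounds shown here alone, whether a methylamino, hydroxy or methoxy group on this carbon would match amino stays open. So does whether the gain from amino carries over to other cores.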